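Benzyloxy for methoxy in a level cytotoxicity series

The compounds below may be only part of what the source reports. "The series", "measured", "known", "first", "only" and "open" are said of these compounds alone.

Measured in an ADME assay on CCRF-CEM cells (Homo sapiens) for cytotoxicity, with a stated time of 4 days; a lower number here means that less compound is tolerated, a higher number that more compound is tolerated:
Compound 1 `Cc1cn([C@@H]2O[C@H](CO[Si](C)(C)C(C)(C)C)[C@@]3(OS(=O)(=O)C=C3N)[C@H]2O[Si](C)(C)C(C)(C)C)c(=O)n(C(=O)C2CC2)c1=O`: 11000 nM
Compound 2 `COC(=O)CCCC(=O)n1c(=O)c(C)cn([C@@H]2O[C@H](CO[Si](C)(C)C(C)(C)C)[C@@]3(OS(=O)(=O)C=C3N)[C@H]2O[Si](C)(C)C(C)(C)C)c1=O`: 9900 nM
Compound 3 `CNC(=O)CCCC(=O)n1c(=O)c(C)cn([C@@H]2O[C@H](CO[Si](C)(C)C(C)(C)C)[C@@]3(OS(=O)(=O)C=C3N)[C@H]2O[Si](C)(C)C(C)(C)C)c1=O`: 9100 nM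

Compound 2 gives 9900 nM and lies within the scatter of both other compounds, so the three values form a single level with no order among them. Compound 4 `Cc1cn([C@@H]2O[C@H](CO[Si](C)(C)C(C)(C)C)[C@@]3(OS(=O)(=O)C=C3N)[C@H]2O[Si](C)(C)C(C)(C)C)c(=O)n(C(=O)CCCC(=O)OCc2ccccc2)c1=O` differs from compound 2 in one place: phenyl in place of hydrogen on a saturated chain carbon bound to an oxygen next to a carbonyl group, which is phenyl in place of hydrogen on a saturated chain carbon bound to an oxygen next to a carbonyl group, turning methoxy into benzyloxy. For the measured compounds named here, no measured step adds a ring at this place, so the change itself is untested. The closest evidence is a 1.1-fold lower number from compound 2 to compound 3 (0.04 log units; within the scatter) with methylamino in place of methoxy. The broader replacements, a 1.1-fold lower number from compound 1 to compound 2 (0.05 log units; within the scatter) and a 1.2-fold lower number from compound 1 to compound 3 (0.08 log units; within the scatter), were equally small. On these steps, no change beyond the scatter is expected in this assay, and the range is kept wide because of the untested ring. The expected step is a 1.0-fold lower number from compound 2 to compound 4 (0.02 log units; within the scatter) and stays within the scatter. Compound 4 is estimated at 9500 nM, with an expected range from 5000 nM to 18000 nM.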

Compound 4, half-maximal cytotoxic concentration: 9200 nM
Estimate against measurement, compound 4: 1.0-fold (0.01 log units) above, and the stated range covers the measured number.
By their numbers in this assay, from the lowest: compounds 3, 4, 2 and 1 (each within the scatter of the next).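

In this assay, for the compounds shown here, phenyl in place of hydrogen, turning methoxy into benzyloxy, gives a 1.1-fold lower number from compound 2 to compound 4 (0.03 log units; within the scatter) and so places an aromatic ring at this end of the chain, which no earlier step had tested, without moving compound 4 off the common level. The exchange of methylamino for benzyloxy reads the same, with a 1.0-fold higher number from compound 3 to compound 4 (0.00 log units; within the scatter) as the step, so these two ends of the chain cannot be told apart here, and size up to the benzyl group shows no effect on this number at this place. No available evidence bears on why the values stay level.

Going by these compounds, whether that level would hold with a carboxylic acid or an amine at the end of the chain, or with a longer chain, stays open. All four compounds share one core, so the same question stands for any other core.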